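The compounds below may be only part of what the source reports. "The series", "measured", "known", "first", "only" and "open" are said of these compounds alone.

In an ADME assay on Raji cells (Homo sapiens) for cytotoxicity, with a stated time of 72 h (on this read-out lower numbers stand for an effect already at smaller amounts and higher numbers for an effect only at larger amounts of compound), three compounds with the same core have been measured. Going by the values given here, compound 3 `COC(=O)c1ccc(NC(=O)Nc2cc(C)nc3ccccc23)cc1` gives 17000 nM, the only actual number so far. Compound 1 `Cc1cc(NC(=O)Nc2ccc(C(C)(C)C)cc2)c2ccccc2n1` reads > 25000 nM, which is a limit of the assay and not a number. Compound 2 `CC(=O)c1ccc(NC(=O)Nc2cc(C)nc3ccccc23)cc1` reads > 25000 nM, which is again a limit.

Compound 4 `Cc1cc(NC(=O)Nc2ccc(O)cc2)c2ccccc2n1` has not yet been measured. It carries hydroxy in place of methoxycarbonyl on an aromatic carbon. The measured steps that bear on this change are those at the same place on the molecule. One is an at least 1.4-fold lower number from compound 1 to compound 3 (0.16 log units; that floor lies within the scatter), another is an at least 1.4-fold lower number from compound 2 to compound 3 (0.16 log units; that floor lies within the scatter), and the third is a step that the two limits leave unreadable from compound 1 to compound 2. None of them shows a change beyond the scatter, although none involves hydroxy, so they offer only weak guidance.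

The expected result is a 1.2-fold higher number from compound 3 to compound 4 (0.07 log units; within the scatter), with no step beyond the scatter in either direction. The estimated value for compound 4 is 20000 nM, with an expected range from 8000 nM to 45000 nM.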

Compound 4, half-maximal effective concentration: > 25000 nM
Compound 4: no number, only a limit; the forecaster's own chance of this, stated with the estimate: 55%; middle value at least 1.2-fold (0.09 log units) away from the limit.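

In this assay, hydroxy in place of methoxycarbonyl gives an at least 1.4-fold higher number from compound 3 to compound 4 (0.16 log units; that floor lies within the scatter), so even this change, the first here to bring a hydrogen-bond donor to this position, shows no step beyond the scatter. Compound 4 gives > 25000 nM, which is a limit of the assay and not a number. The steps to compound 4 from compound 1 and from compound 2 join two limits and cannot be read, and most of the series now sits at the same ceiling: the limit of > 25000 nM in this assay, at which 3 of the 4 values shown sit.

Going by these compounds alone, compound 3 remains the only compound with an actual number, so whether any group at this position truly changes the read-out stays open. An amine, a carboxylic acid or a longer chain on this aromatic carbon could answer that only if it gave a number rather than a limit.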